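This account rests on a few compounds, and the source may have more. Where it says the series, first, only, none or still open, it means among the compounds named here.

Values in a functional assay on SK-BR-3 cells (Homo sapiens) for antiproliferative activity (a lower number here means a stronger inhibitor, a higher number a weaker inhibitor), are as follows:
- compound 1 `CC(C)=CCc1cc(C(=O)Nc2cc3ccc(OCC4CCCN(C)C4)c(C)c3oc2=O)ccc1O` gives 1300 nM
- compound 2 `CCN(CC)CCCOc1ccc2cc(NC(=O)c3ccc(O)c(CC=C(C)C)c3)c(=O)oc2c1C` gives 4900 nM
- compound 3 `CC(C)=CCc1cc(C(=O)Nc2cc3ccc(OCCCNCC(=O)O)c(C)c3oc2=O)ccc1O` gives 7570 nM

Compound 3 stands at the high end of these numbers, beyond the scatter against compound 1 (a 5.8-fold higher number from compound 1 to compound 3 (0.77 log units; beyond the scatter)). Compound 4 `CC(C)=CCc1cc(C(=O)Nc2cc3ccc(OCCCN(C)c4ccccc4)c(C)c3oc2=O)ccc1O` carries methyl(phenyl)amino in place of (carboxymethyl)amino on a saturated chain carbon, three bonds along the chain from an oxygen on an aromatic ring. Going by the values given here, the one measured exchange at this place stayed within the scatter (a 1.5-fold higher number from compound 2 to compound 3 (0.19 log units; within the scatter)). A wider change of the side chain gave a modest step (a 3.8-fold higher number from compound 1 to compound 2 (0.58 log units; beyond the scatter)). Among the compounds with values here, no measured compound carries a phenyl group on this nitrogen, so the evidence is indirect. A modest move to a lower number is expected in this assay (a 2.5-fold lower number from compound 3 to compound 4 (0.40 log units; beyond the scatter)). Compound 4 is estimated at 3000 nM (range 900 nM to 9000 nM).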

Compound 4, half-maximal inhibitory concentration: > 50000 nM
Compound 4 ended at the assay's limit; the forecaster's own chance of this, stated with the estimate: 8%; at least 16-fold (1.22 log units) between middle value and limit.
By their numbers in this assay, from the lowest: compound 1; then compounds 2 and 3 (each within the scatter of the next). At a limit, above all of these: compound 4.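

In this assay compound 4 gives > 50000 nM, a limit of the assay and not a number. Methyl(phenyl)amino on this chain moves the number beyond the scatter, with an at least 6.6-fold higher number from compound 3 to compound 4 (0.81 log units; beyond the scatter) and an at least 10-fold higher number from compound 2 to compound 4 (1.00 log units; beyond the scatter), whereas the exchange of diethylamino for (carboxymethyl)amino stayed within it. Against the 1-methylpiperidin-3-yl side chain the step is large: an at least 38-fold higher number from compound 1 to compound 4 (1.58 log units; beyond the scatter).

On these data alone, it remains open whether the phenyl ring on the nitrogen alone accounts for this step. A benzylamine or a morpholine on the same chain would test that.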